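Lactam in place of amino ester on the shared core

The source may report more compounds than this note shows. Statements on the series, on what has been measured and on what is new or still open speak of the compounds shown alone.

Of the compounds shown here, two have numbers so far. Compound 1 `CCOC(=O)C(C)Nc1cccc2c(S(=O)(=O)Nc3onc(C)c3C)cccc12` is assessed in an assay on VSM-A10 cells for antagonist activity at Endothelin-1 receptor (Rattus norvegicus) (a higher number here means a weaker inhibitor, a lower number a stronger inhibitor), and gives 400 nM. Compound 2 `Cc1noc(NS(=O)(=O)c2ccc(NC(=O)CN)cc2)c1C` gives 6500 nM in this assay. Of the two values, compound 1 has the lower one, and the gap to compound 2 lies beyond the scatter; the two differ in more than one place, so nothing is attributed to any single change between them.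

Compound 3 `Cc1noc(NS(=O)(=O)c2cccc3c(N4CCCCC4=O)cccc23)c1C` is not yet measured in this assay. It differs from compound 1 by one change, (2-oxopiperidin-1-yl in place of (1-(ethoxycarbonyl)ethyl)amino on an aromatic carbon). Among the measured compounds shown here, no step between measured compounds covers this change, so the expectation rests on compound 1 alone. The step from compound 1 to compound 3, a 1.5-fold higher number from compound 1 to compound 3 (0.18 log units; within the scatter), is expected to be small, at most a modest move toward a higher number, and may well fall within the scatter. For compound 3 the value in this assay is estimated at 600 nM, with a range from 150 nM to 2500 nM.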

Compound 3, half-maximal inhibitory concentration: 270 nM
Estimate against measurement, compound 3: 2.2-fold (0.35 log units) above; measured number inside the range.
By their numbers in this assay, from the lowest: compounds 3 and 1 (each within the scatter of the next); then compound 2.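

In this assay, putting 2-oxopiperidin-1-yl in place of (1-(ethoxycarbonyl)ethyl)amino on this aromatic carbon gives a 1.5-fold lower number from compound 1 to compound 3 (0.17 log units; within the scatter), so the two groups cannot be told apart here. The number therefore holds at this level with a six-membered non-aromatic ring in place of the open chain, and with the group's hydrogen-bond donor count going from 1 to 0, so neither the chain nor that donor is required at this position. Nothing available bears on why the two groups read alike.

Still open, going by these compounds, is whether the carbonyl of the ring matters, which a piperidin-1-yl group would address, and whether ring size matters, which a 2-oxopyrrolidin-1-yl group would address. Also open, on these data alone, is how a carboxylic acid in place of the ethyl ester on the open chain would read.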